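This account rests on a few compounds, and the source may have more. Where it says the series, first, only, none or still open, it means among the compounds named here.

Compound 1 `NC1=NC2(CCSCC2)N(OCCCOc2ccc(Br)cc2)C(N)=N1`: 440 nM
Compound 2 `NC1=NC2(CCOCC2)N(OCCCOc2cccc(Cl)c2Cl)C(N)=N1`: 140 nM
Compound 3 `NC1=NC2(CCOCC2)N(OCCCOc2ccc(Cl)cc2Cl)C(N)=N1`: "not determined" (no result reported)

For the measured compounds named here, in a functional assay on MDA-MB-231 cells (Homo sapiens) for antiproliferative activity, read by MTT assay, with a stated time of 72 h (on this read-out higher numbers stand for weaker inhibition and lower numbers for stronger inhibition), compound 1 gives the higher of the two reported numbers; compound 2 gives 140 nM, a lower number that lies beyond the usual scatter, though the two differ in more than one place and no single step links them. For compound 3 no result was reported in this assay. Compound 4 `NC1=NC2(CCSCC2)N(OCCCOc2ccc(Cl)cc2)C(N)=N1` differs from compound 1 in one place: chloro in place of bromo on an aromatic carbon. An exchange of one halogen for another at the same position is expected to move the number little, so the step from compound 1 to compound 4 in this assay is estimated to stay within the scatter, a 1.1-fold higher number from compound 1 to compound 4 (0.06 log units; within the scatter). Compound 4 is therefore expected to give about 500 nM, within a range of 250 nM to 1000 nM.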

Compound 4, half-maximal inhibitory concentration: 350 nM
The estimate for compound 4 lay 1.4-fold (0.15 log units) above the measured number, and the stated range covers the measured number.
By their numbers in this assay, from the lowest: compound 2; then compounds 4 and 1 (each within the scatter of the next).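

In this assay, chloro in place of bromo on an aromatic carbon, para to a large group, gives a 1.3-fold lower number from compound 1 to compound 4 (0.10 log units; within the scatter). For the compounds shown here, this is the first comparison in the set that isolates a single place, and it shows that the two halogens cannot be told apart at this position on this read-out. Nothing available explains this result.

Going by these compounds, whether an amine or a methoxy group on the same carbon would give a similar number remains open. On these data alone, it is also open whether this halogen exchange would behave the same way on the core of compound 2.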